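The source may report more compounds than this note shows. Statements on the series, on what has been measured and on what is new or still open speak of the compounds shown alone.

In a functional assay on HCT-116 cells (Homo sapiens) for antiproliferative activity, read by CCK-8 assay, with a stated time of 72 h, tested at 2 uM (on this read-out lower numbers stand for a weaker effect and higher numbers for a stronger effect at the one concentration tested), the three measured compounds stand as follows:

compound 1, `CCC(C)n1cnc2c(NCc3ccc(C(=O)Nc4ccccc4N)cc3)nc(Cl)nc21`, 74.6%
compound 2, `CCCCn1cnc2c(NCc3ccc(C(=O)Nc4ccccc4N)cc3)nc(Cl)nc21`, 4.89%
compound 3, `CC(C)n1cnc2c(NCc3ccc(C(=O)Nc4ccccc4N)cc3)nc(Cl)nc21`, 73.2%

Compound 3 sits second highest of the three numbers; its nearest step, a number 1.4 percentage points lower from compound 1 to compound 3 (within the scatter), lies within the scatter, and its furthest is compound 2, whose step of a number 68.3 percentage points higher from compound 2 to compound 3 (beyond the scatter) is large. For the measured compounds named here, the only other measured step, a number 69.7 percentage points lower from compound 1 to compound 2 (beyond the scatter), is likewise large and concerns the same position, the group on the aromatic nitrogen of the shared core.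

Compound 4, `Nc1ccccc1NC(=O)c1ccc(CNc2nc(Cl)nc3c2ncn3Cc2ccccc2)cc1`, differs from compound 3 in exactly that place: benzyl in place of isopropyl on an aromatic nitrogen. Going by the values given here, no measured step covers a benzyl group here, so the outcome cannot be read off directly. Two of the three groups already tried gave high numbers, while butyl gave a low one, so this position clearly can move the read-out in either direction by a large step. The expected result for compound 4 is therefore placed between these extremes, with a wide range: in this assay compound 4 is estimated at 40%, within 5% to 80%, which would mean an expected step of a number 33.2 percentage points lower from compound 3 to compound 4 (beyond the scatter).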

Compound 4, a percentage reported as inhibition, at one concentration (the size of the read-out at that concentration, not a potency): 7.7%
For compound 4 the middle estimate is 32.3 percentage points above the measured one; measured number inside the range.
By their numbers in this assay, from the lowest: compounds 2 and 4 (each within the scatter of the next); then compounds 3 and 1 (each within the scatter of the next).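

In this assay, benzyl on the aromatic nitrogen falls with butyl, not with the two groups that gave high numbers. The step is large in a number 65.5 percentage points lower from compound 3 to compound 4 (beyond the scatter) and again in a number 66.9 percentage points lower from compound 1 to compound 4 (beyond the scatter), while a number 2.8 percentage points higher from compound 2 to compound 4 (within the scatter) stays small. The low number therefore does not belong to the open butyl chain alone: a group carrying a six-membered aromatic ring of carbon only gives the same result, so two quite different groups now sit together at the low end, and the high numbers rest on isopropyl and sec-butyl only. Nothing measured here explains why these four groups divide in this way.

The compounds shown leave open where the line between high and low numbers falls among other small groups on this nitrogen, such as ethyl, cyclopropyl, cyclopentyl or tert-butyl. They also leave open whether a longer link to the ring, as in 2-phenylethyl, or a methoxy group on the benzyl ring would change the low number seen with benzyl.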